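The compounds below may be only part of what the source reports. "The series", "measured", "known", "first", "only" and "open" are said of these compounds alone.

Values measured in a physicochemical assay for lipophilicity, using the shake flask method, at pH 7.4 (on this read-out higher numbers stand for higher lipophilicity and lower numbers for lower lipophilicity), are as follows

compound 1 `CN(C)[C@H]1CC[C@H](Nc2ncnc3sccc23)CC1` gives 0.1
compound 2 `CN(C)[C@H]1CC[C@H](Nc2ncnc3[nH]cc(C4CC4)c23)CC1` gives 0.9
compound 3 `CC(=O)N1CCN([C@H]2CC[C@H](Nc3ncnc4[nH]cc(C5CCOCC5)c34)CC2)CC1` gives 1.3

Compound 3 stands highest of the three, and its value lies beyond the scatter from both compound 2 and compound 1. Compound 4 `CN(C)C(=O)N1CCN([C@H]2CC[C@H](Nc3ncnc4[nH]cc(C5CCOCC5)c34)CC2)CC1` differs from compound 3 by dimethylamino in place of methyl on a carbonyl carbon. Going by the values given here, no two measured compounds differ in one place only, so no measured step guides this change. A small rise in this assay is expected, probably not beyond the scatter. The expected a number 0.20 log units higher from compound 3 to compound 4 (within the scatter) is therefore modest and upward. Compound 4 is estimated at 1.5 with an expected range from 1.1 to 1.9 for the coming measurement.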

Compound 4, distribution coefficient: 1.5
Compound 4: middle estimate and measured number agree at the digits printed, within the range that was stated.
By their numbers in this assay, from the lowest: compound 1; then compound 2; then compounds 3 and 4 (each within the scatter of the next).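

In this assay, going by these compounds alone, the change from 4-acetylpiperazin-1-yl to 4-(dimethylcarbamoyl)piperazin-1-yl gives a number 0.20 log units higher from compound 3 to compound 4 (within the scatter) and is the first one-place step. On this carbonyl carbon, dimethylamino in place of methyl therefore gives no difference that can be told from the scatter, so the read-out tolerates this exchange here. No measured evidence bears on the reason for this result. Open, as far as these compounds go, is whether methoxy or a longer chain such as propyl on the same carbonyl carbon would also stay within the scatter of compound 3, and whether the step carries over to other parts of the series.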